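Inverting two stereocentres of a long-lived stereoisomer

A few compounds are considered here, and "the series" means these few. Any claim that something is new, unique, unknown or untested is made for them only; others in the source may bear on it.

Measured in an ADME assay on Jejunum (Mus musculus, strain C57BL/6) for metabolic stability, read by HPLC, with a stated time of 12 h (a lower number here means that the compound disappears faster, a higher number that the compound lasts longer), as a half-life:
compound 1 `O=C(O)[C@H](CO)NC(=O)[C@H]1C[C@H](O)CN1` gives > 12 h as a limit
compound 2 `O=C(O)[C@@H](CO)NC(=O)[C@H]1C[C@@H](O)CN1` gives > 12 h as a limit
compound 3 `O=C(N[C@H](CO)C(=O)O)[C@@H]1C[C@@H](O)CN1` gives 0.33 h as a number

Compound 2 gives > 12 h in this assay and this is a limit, not a number. Compound 1 gives > 12 h and this too is a limit. Only compound 3 gives a true number, 0.33 h in this assay as noted above.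

Compound 4 `O=C(O)[C@H](CO)NC(=O)[C@@H]1C[C@@H](O)CN1` comes from compound 2 by configuration alone: the two compounds have the same atoms and bonds and differ only in configuration as drawn: 2 of 3 stereo elements differ; a stereocentre at a saturated chain carbon is drawn R in compound 2 and S in compound 4; a stereocentre at a saturated ring carbon is drawn R in compound 2 and S in compound 4 and nothing leaves or enters.

The closest measured change is an at least 36-fold lower number from compound 2 to compound 3 (1.56 log units; beyond the scatter) and it inverts one ring carbon from R to S, the kind of inversion that compound 4 also carries. That large drop rests on configuration alone because of the fact that compounds 2 and 3 differ only in the configuration as drawn and the same holds for an at least 36-fold lower number from compound 1 to compound 3 (1.56 log units; beyond the scatter) because of the fact that compounds 1 and 3 differ only in the configuration as drawn in that pair. The chain carbon also changes in a step that the two limits leave unreadable from compound 1 to compound 2 and so its share stays unread.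

Going by the values given here, a large drop is therefore expected, close in size to the one seen for compound 3 at 0.33 h in this assay as its half-life. The expected change is an at least 30-fold lower number from compound 2 to compound 4 (1.47 log units; beyond the scatter) on this estimate. Compound 4 is expected at 0.4 h (range 0.1 h to 3 h).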

Compound 4, half-life: 0.35 h
Compound 4: the middle estimate sits 1.1-fold (0.06 log units) above what was measured, and the stated range covers the measured number.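

Inverting the saturated chain carbon alone gives, in this assay, a 1.1-fold higher number from compound 3 to compound 4 (0.03 log units; within the scatter); this is the first reading of that centre on its own, and with the ring carbons as drawn in this pair it changes nothing beyond the scatter. The large drop also appears with the chain carbon left as drawn, in an at least 34-fold lower number from compound 1 to compound 4 (1.53 log units; beyond the scatter), where only the two saturated ring carbons are inverted, and it appears again in an at least 34-fold lower number from compound 2 to compound 4 (1.53 log units; beyond the scatter), where one ring carbon and the chain carbon are inverted. Among these four compounds, the short half-lives therefore go with the ring configuration shared by compound 3 and compound 4 and not with the chain carbon, while the starting points of both large steps, compound 1 and compound 2, are limits and not numbers.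

As far as these compounds go, the step between compound 1 and compound 2 cannot be read, so it stays open whether the chain carbon is equally silent with the ring carbons drawn as in those two compounds. From the compounds shown here alone, it also stays open whether an amine or a longer chain on the shared core would show the same dependence on configuration.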